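Fluoro for Chloro, Repeated on an Unformylated Core

The source may report more compounds than this note shows. Statements on the series, on what has been measured and on what is new or still open speak of the compounds shown alone.

Measured compounds in a functional assay on the whole organism (strain Wistar) for inhibition, with Rattus norvegicus as the target, read by paw edema, with stated times of 30 min and 60 min, at a dose of 50 mg/kg by the oral route; on this read-out higher numbers stand for more inhibition at the one dose given (going by the name of the read-out) and lower numbers for less inhibition:
compound 1, `O=CN1N=C(c2ccc(F)cc2)CC1c1cn(-c2ccccc2)nc1-c1ccc(Cl)c(Cl)c1`, 56.5%
compound 2, `O=CN1N=C(c2ccc(Cl)cc2)CC1c1cn(-c2ccccc2)nc1-c1ccc(Cl)c(Cl)c1`, 51.1%
compound 3, `Clc1ccc(C2=NNC(c3cn(-c4ccccc4)nc3-c3ccc(Cl)c(Cl)c3)C2)cc1`, 45.8%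

Compound 2 and compound 1 differ only in one place, (fluoro in place of chloro on an aromatic carbon), and the step is a number 5.4 percentage points higher from compound 2 to compound 1 (within the scatter). Compound 2 and compound 3 differ in their cores, (hydrogen in place of formyl on an amine nitrogen in a ring), with the step of a number 5.3 percentage points lower from compound 2 to compound 3 (within the scatter). Compound 3 gives the lowest of the three numbers, and against compound 1 the gap is wider, as the two values show.

Compound 4, `Fc1ccc(C2=NNC(c3cn(-c4ccccc4)nc3-c3ccc(Cl)c(Cl)c3)C2)cc1`, is not yet measured. It carries the core of compound 3 and differs from it by fluoro in place of chloro on an aromatic carbon. This is the same change that led from compound 2 to compound 1, and the place is the same word for word. Compound 4 is therefore expected to move from compound 3 by about a number 5.2 percentage points higher from compound 3 to compound 4 (within the scatter), because the earlier step of a number 5.4 percentage points higher from compound 2 to compound 1 (within the scatter) stayed within the scatter. Compound 4 is estimated at 51%, with an expected range from 40% to 62%.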

Compound 4, a percentage reported as inhibition, in the whole organism at one dose (the size of the read-out at that dose, not a potency): 40.5%
For compound 4 the middle estimate is 10.5 percentage points above the measured one; the range from low to high includes it.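

In this assay, the change from 4-chlorophenyl to 4-fluorophenyl on the core without the formyl group gives a number 5.3 percentage points lower from compound 3 to compound 4 (within the scatter), and this step cannot be told apart from the one on the formylated core: the same change on two cores in this assay, a number 5.4 percentage points higher (within the scatter) from compound 2 to compound 1 and a number 5.3 percentage points lower (within the scatter) from compound 3 to compound 4, 10.7 percentage points apart, within the scatter of two such steps

Hydrogen in place of formyl on the fluoro pair gives a number 16 percentage points lower from compound 1 to compound 4 (beyond the scatter), and although this step alone lies beyond the scatter, it cannot be told apart from the same change on the chloro pair: the same change on two cores in this assay, a number 5.3 percentage points lower (within the scatter) from compound 2 to compound 3 and a number 16 percentage points lower (beyond the scatter) from compound 1 to compound 4, 10.7 percentage points apart, within the scatter of two such steps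

This shows that both changes carry from one core to the other within what the scatter allows, but it does not give the halogen exchange a direction, since neither of its steps lies beyond the scatter, and a single pair of steps per change cannot show how either would behave on other cores.

The compounds shown leave open what a methoxy group, a nitrile or an amine would do in place of the chloro or fluoro. They also leave open whether an acetyl group on the amine nitrogen in the ring would read like formyl or like hydrogen.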